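Naphthyl for methoxyphenyl on the pyrazoline-linked core

A few compounds are considered here, and "the series" means these few. Any claim that something is new, unique, unknown or untested is made for them only; others in the source may bear on it.

Compound 2 `COc1ccc(C2=NN(C3=NC(=O)/C(=C4\C(=O)Nc5ccccc54)S3)C(c3ccc(OC)cc3)C2)cc1` shows the highest of the two numbers recorded so far in a functional assay on cells (Cancer cell lines, Homo sapiens) for cytotoxicity, read by sulforhodamine B assay, with a stated time of 48 h; a lower number here means a stronger inhibitor of growth, a higher number a weaker inhibitor of growth; its nearest neighbour is compound 1 `COc1ccc(C2CC(c3ccccc3)=NN2C2=NC(=O)/C(=C3\C(=O)Nc4ccccc43)S2)cc1`. In this assay compound 1 gives 4270 nM, whereas compound 2 gives 100000 nM. Among the measured compounds shown here, the single measured step, a 23-fold higher number from compound 1 to compound 2 (1.37 log units; beyond the scatter), is large and well beyond the scatter. Compound 3 `COc1ccc(C2CC(c3ccc4ccccc4c3)=NN2C2=NC(=O)/C(=C3\C(=O)Nc4ccccc43)S2)cc1` differs from compound 2 by naphthalen-2-yl in place of 4-methoxyphenyl on a carbon with a double bond to nitrogen. For the measured compounds named here, this change removes the group whose introduction produced that large rise, and enlarges the aromatic system at the same carbon; no measured step covers the naphthalen-2-yl group itself. Because of a 23-fold higher number from compound 1 to compound 2 (1.37 log units; beyond the scatter), a clearly lower number for compound 3 than for compound 2 is expected, of the order of a 17-fold lower number from compound 2 to compound 3 (1.22 log units; beyond the scatter). Compound 3 is therefore estimated at 6000 nM in this assay, with a range from 1500 nM to 30000 nM.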

Compound 3, concentration for total growth inhibition: 13600 nM
Beside the measured number, compound 3's estimate is 2.3-fold (0.36 log units) below it; measured number inside the range.
By their numbers in this assay, from the lowest: compound 1; then compound 3; then compound 2.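

In this assay, the step of a 7.4-fold lower number from compound 2 to compound 3 (0.87 log units; beyond the scatter) shows that naphthalen-2-yl, on the carbon with a double bond to nitrogen, gives a much lower number than 4-methoxyphenyl, even though it is the larger group by heavy atoms. The step of a 3.2-fold higher number from compound 1 to compound 3 (0.50 log units; beyond the scatter) shows that it does not match phenyl at this carbon, so among these three groups phenyl gives the lowest number and 4-methoxyphenyl the highest. No supporting measurement bears on why the numbers fall in this order.

The compounds shown leave open whether a chloro, hydroxyl or amino group on that phenyl ring would raise the number as methoxy does. From the compounds shown here alone, it also remains open whether this order would hold if the 4-methoxyphenyl group on the neighbouring ring atom were replaced by plain phenyl.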